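Changing the Amide Aryl Group in a Dopamine Receptor Series

The source may report more compounds than this note shows. Statements on the series, on what has been measured and on what is new or still open speak of the compounds shown alone.

Three compounds were measured in a functional assay on HEK293 cells for agonist activity at D(4) dopamine receptor (Homo sapiens), read by FLIPR; a lower number here means that less compound is needed, a higher number that more compound is needed for the effect:

compound 1, `O=C(CN1CCC(c2cccc[n+]2[O-])CC1)Nc1ccc(F)cc1F`: 103 nM
compound 2, `Cc1cc(F)ccc1NC(=O)CN1CCC(c2cccc[n+]2[O-])CC1`: 60 nM
compound 3, `CCc1cccc(NC(=O)CN2CCC(c3cccc[n+]3[O-])CC2)c1`: 95 nM

All three share one core and differ only in the aryl group attached to the amide-type nitrogen. Compound 3 stands second highest of the three numbers, yet every gap between them is small: a 1.1-fold lower number from compound 1 to compound 3 (0.04 log units; within the scatter) and a 1.6-fold higher number from compound 2 to compound 3 (0.20 log units; within the scatter), and also a 1.7-fold lower number from compound 1 to compound 2 (0.23 log units; within the scatter). For the measured compounds named here, no pair is separated by more than the usual scatter, so the three aryl groups tried so far behave alike.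

Compound 4, `Cc1cc(Br)ccc1NC(=O)CN1CCC(c2cccc[n+]2[O-])CC1`, is the next member. Its difference from compound 3 is 4-bromo-2-methylphenyl in place of 3-ethylphenyl on an amide-type nitrogen. Compound 4 is thus the bromine counterpart of compound 2, which gave 60 nM. Going by the values given here, no measured step covers a bromine in place of a fluorine, so only the three small steps above bear on it, and they all lie within the scatter. The step of a 1.4-fold lower number from compound 3 to compound 4 (0.13 log units; within the scatter) is therefore expected to stay within the scatter. For compound 4 the estimate is 70 nM, with a range from 30 nM to 170 nM.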

Compound 4, half-maximal effective concentration: 66 nM
Beside the measured number, compound 4's estimate is 1.1-fold (0.03 log units) above it, and the stated range covers the measured number.
By their numbers in this assay, from the lowest: compounds 2, 4, 3 and 1 (each within the scatter of the next).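

In this assay, for the compounds shown here, the direct swap of one halogen for another gives a 1.1-fold higher number from compound 2 to compound 4 (0.04 log units; within the scatter), so this change, which the earlier compounds did not cover, leaves the two indistinguishable. The whole aryl group can also change without a clear effect, with a 1.4-fold lower number from compound 3 to compound 4 (0.16 log units; within the scatter) and a 1.6-fold lower number from compound 1 to compound 4 (0.19 log units; within the scatter), so all four aryl groups on the amide-type nitrogen now read alike in this assay. No measured evidence offers a reason for this flat picture.

As far as these compounds go, it remains open whether the picture would hold for an aryl group carrying an amine or a carboxylic acid, or for a longer chain on the amide-type nitrogen. From the compounds shown here alone, it is also open whether a change in the shared core would move the number beyond the scatter.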